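Working notes: from compound 3 to compound 4

A few compounds are considered here, and "the series" means these few. Any claim that something is new, unique, unknown or untested is made for them only; others in the source may bear on it.

Measured so far in a functional assay on P388 cells (Mus musculus) (a lower number here means a stronger inhibitor, a higher number a weaker inhibitor), as half-maximal inhibitory concentrations

compound 1 `COc1ccc(/C=C/C(=O)Oc2ccc(/C=C3\CCCC(CN(C)C)C3=O)cc2)cc1` at 2410 nM
compound 2 `CN(C)CC1CCC/C(=C\c2ccc(OC(=O)/C=C/c3ccc(Br)cc3)cc2)C1=O` at 4030 nM
compound 3 `COc1ccc(C(=O)Oc2ccc(/C=C3\CCCCC3=O)cc2)cc1` at > 50000 nM as a limit of the assay

Compound 3 has no number, only the limit > 50000 nM in this assay as its place in the series.

Compound 4 `COc1ccc(C(=O)Oc2ccc(/C=C3\CCCC(CN(C)C)C3=O)cc2)cc1` differs from compound 3 by one change (dimethylamino)methyl in place of hydrogen on a saturated ring carbon with (dimethylamino)methyl in place of hydrogen on a saturated ring carbon. For the measured compounds named here, no measured step covers this change. Going by the values given here, the only measured step, a 1.7-fold higher number from compound 1 to compound 2 (0.22 log units; within the scatter), is bromo in place of methoxy on an aromatic carbon, so it bears only on how little that exchange moved the number.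

The closer evidence is indirect. Compound 1 gives 2410 nM and compound 2 gives 4030 nM with the (dimethylamino)methyl group that compound 3 lacks, although their ester part differs from that of compound 4.

On the values of compound 1 and compound 2, a clear step to a lower number is expected in this assay, with its size uncertain. The estimated step is an at least 10-fold lower number from compound 3 to compound 4 (1.00 log units; beyond the scatter) as a working expectation. Compound 4 is estimated at 5000 nM with an expected range from 1500 nM to 20000 nM for the measurement.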

Compound 4, half-maximal inhibitory concentration: 332 nM
Compound 4: middle estimate off by 15-fold (1.18 log units), on the high side; the measured number lies below the stated range.
By their numbers in this assay, from the lowest: compound 4; then compounds 1 and 2 (each within the scatter of the next). At a limit, above all of these: compound 3.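

For the compounds shown here, compound 3 and compound 4 share the same ester part, so in this assay the effect of (dimethylamino)methyl in place of hydrogen on a saturated ring carbon can now be read directly, which no earlier pair allowed: an at least 150-fold lower number from compound 3 to compound 4 (2.17 log units; beyond the scatter). This size is only a bound, and the number for compound 3 is a limit of the assay: the limit of > 50000 nM in this assay, at which 1 of the 4 values shown sits.

With the (dimethylamino)methyl group present on both sides, 4-methoxyphenyl in place of 2-(4-bromophenyl)ethenyl on a carbonyl carbon gives a 12-fold lower number from compound 2 to compound 4 (1.08 log units; beyond the scatter), and 4-methoxyphenyl in place of 2-(4-methoxyphenyl)ethenyl gives a 7.3-fold lower number from compound 1 to compound 4 (0.86 log units; beyond the scatter), so the carbonyl substituent also matters in this series, whereas the earlier exchange of bromo for methoxy stayed within the scatter.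

The compounds shown leave open whether the step from hydrogen depends on the nitrogen, which a methyl or hydroxymethyl group on the same ring carbon would test. Also open, going by these compounds, is how far it holds for a larger amine such as piperidinylmethyl, for a longer chain carrying the dimethylamino group, or for an amide in place of the ester.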